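Swapping one aromatic group on compound 3

The source may report more compounds than this note shows. Statements on the series, on what has been measured and on what is new or still open speak of the compounds shown alone.

In a functional assay on BGC-823 cells (Homo sapiens) for inhibition, read by sulforhodamine B assay, with a stated time of 3 days (on this read-out higher numbers stand for weaker inhibition and lower numbers for stronger inhibition), compound 1 `O=C1Nc2ccc([N+](=O)[O-])cc2/C1=C\C(=O)c1ccc(C2CCCCC2)cc1` gives 5900 nM and compound 2 `O=C1Nc2ccc(F)cc2/C1=C\C(=O)c1cnc2ccc(Cl)nn12` gives 8020 nM while compound 3 `COc1ccc(C(=O)Nc2ccc3c(c2)/C(=C/Nc2cccc(N4CCN(C)CC4)c2)C(=O)N3)cc1` gives 3170 nM as its result. Going by the values given here, these three compounds are the only measurements so far. Compound 3 has the lowest number of the three, but that is no clear lead over compound 1, since the gap between those two lies within the usual scatter of repeated measurements. Compound 2 has a higher number than compound 3, and that gap lies beyond the scatter.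

Compound 4 `CN1CCN(c2cccc(N/C=C3\C(=O)Nc4ccc(NC(=O)c5cccc(F)c5)cc43)c2)CC1` has not yet been measured. It has 3-fluorophenyl in place of 4-methoxyphenyl on a carbonyl carbon, and the exchange counts as 3-fluorophenyl in place of 4-methoxyphenyl on a carbonyl carbon with the rest of compound 3 unchanged. Among the compounds with values here, no two measured compounds differ in only one place, so the data do not show what this change does. The best guide is therefore compound 3 with its 3170 nM as the starting point. The expected step of a 1.1-fold lower number from compound 3 to compound 4 (0.02 log units; within the scatter) in this assay is estimated to stay within the scatter, with neither direction favoured. Compound 4 is expected to give 3000 nM with an estimated range from 1200 nM to 7500 nM in this wide span.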

Compound 4, half-maximal inhibitory concentration: 8500 nM
Estimate against measurement, compound 4: 2.8-fold (0.45 log units) below; the measured number lies above the stated range.
By their numbers in this assay, from the lowest: compounds 3, 1, 2 and 4 (each within the scatter of the next, the first and the last beyond it).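

Going by these compounds alone, this is the first pair in the set that differs in one place only, and it gives the first direct reading of a change at this position: 3-fluorophenyl in place of 4-methoxyphenyl on a carbonyl carbon gives a 2.7-fold higher number from compound 3 to compound 4 (0.43 log units; beyond the scatter) in this assay with the rest of compound 3 unchanged. The group on this carbonyl is therefore not a silent part of the molecule, as this single exchange moves the number past the usual scatter, towards weaker inhibition. Nothing measured here explains the step, and the data cannot say whether losing the methoxy group, gaining the fluorine or moving the substituent on the ring accounts for it.

The exchange alters both the substituent and its place on the ring, and the compounds shown leave open whether 4-fluorophenyl or 3-methoxyphenyl would sit closer to compound 3 or to compound 4. Also open, from the compounds shown here alone, is how unsubstituted phenyl or 4-aminophenyl would behave on this carbonyl, and whether the same exchange would have a similar effect on another core.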